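Oxime and methyl oxime hydroxamates: halogen swap notes

This account rests on a few compounds, and the source may have more. Where it says the series, first, only, none or still open, it means among the compounds named here.

Working notes on a short hydroxamic acid series assayed in a functional assay on NCI-H460 cells (Homo sapiens) for antiproliferative activity, read by sulforhodamine B assay, with a stated time of 48 h; on this read-out lower numbers stand for stronger inhibition and higher numbers for weaker inhibition. Compound 1 `O=C(CCCCCCN1C(=O)/C(=N\O)c2cc(F)ccc21)NO` carries a free oxime and a fluoro substituent; in this assay compound 1 gives 1500 nM. Compound 2 `O=C(CCCCCCN1C(=O)/C(=N\O)c2cc(Cl)ccc21)NO` differs by chloro in place of fluoro on an aromatic carbon and in this assay compound 2 gives 850 nM. The measured step is a 1.8-fold lower number from compound 1 to compound 2 (0.25 log units; within the scatter). Compound 3 `CO/N=C1/C(=O)N(CCCCCCC(=O)NO)c2ccc(F)cc21` carries the methyl oxime ether together with fluoro; in this assay compound 3 gives 970 nM, a number that sits close to the values of compound 2 and compound 1, all three lying within the usual scatter of one another. The difference between the core of compound 1 and the core of compound 3 is not broken down here.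

Compound 4 `CO/N=C1/C(=O)N(CCCCCCC(=O)NO)c2ccc(Cl)cc21` has not yet been measured. It differs from compound 3 by chloro in place of fluoro on an aromatic carbon, which is the same change as that made from compound 1 to compound 2, at the same place on the core; it occurs twice in all among the compounds shown. For compound 4 in this assay the expectation is 550 nM, with a range from 250 nM to 1200 nM. The expected step is a 1.8-fold lower number from compound 3 to compound 4 (0.25 log units; within the scatter), which follows because a 1.8-fold lower number from compound 1 to compound 2 (0.25 log units; within the scatter) and rests on that single earlier pair alone; with one precedent, itself within the scatter, the number is an estimate and a flat outcome would be no surprise.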

Compound 4, half-maximal inhibitory concentration: 760 nM
Compound 4: middle estimate off by 1.4-fold (0.14 log units), on the low side, and the stated range covers the measured number.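

In this assay, chloro in place of fluoro on the methyl oxime ether core gives a 1.3-fold lower number from compound 3 to compound 4 (0.11 log units; within the scatter), and the two instances of this change compare as follows: the same change on two cores in this assay, a 1.8-fold lower number (0.25 log units; within the scatter) from compound 1 to compound 2 and a 1.3-fold lower number (0.11 log units; within the scatter) from compound 3 to compound 4, 1.4-fold (0.14 log units) apart, within the scatter of two such steps

The step therefore reads the same on the free oxime core and the methyl oxime ether core, so within this series the change carries from one core to the other without a detectable difference in its size. This does not show that chloro gives a real gain over fluoro on either core, since each step taken alone lies within the scatter, and agreement between two small steps cannot separate a shared effect from no effect at all; nor does one such comparison establish a rule for cores outside compounds 1 to 4.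

The compounds shown leave open whether bromo, methoxy or nitrile on the same aromatic carbon, or a bare aromatic carbon there, would give a step beyond the scatter on either core. They also leave open whether the same step holds with a longer chain carrying the hydroxamic acid or with a benzyl oxime ether in place of the methyl oxime ether.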